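The compounds below may be only part of what the source reports. "The series", "measured", "known", "first", "only" and "open" are said of these compounds alone.

Measured compounds in a physicochemical assay for lipophilicity, measured as octanol-water partition, with a stated time of 72 h; on this read-out lower numbers stand for lower lipophilicity and higher numbers for higher lipophilicity:
compound 1 `CC(C)NC(=O)NO` gives 0.2;
compound 2 `CCCCNC(=O)NO` gives 0.32;
compound 3 `CCCNC(=O)NO` gives 0.22.

The three compounds share an N-hydroxyurea part and differ only in the alkyl group on the amide-type nitrogen. Compound 1 has the lowest of the three numbers, but its nearest neighbour compound 3 and its furthest neighbour compound 2 both lie within the scatter of it, so no ordering among them can be read from these values. Compound 1 and compound 3 have the same atoms joined differently; the difference between the two cores is not broken down here.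

One structural change occurs twice among the compounds shown. Between compound 3 and compound 2 it reads (methyl in place of hydrogen on a saturated chain carbon, three bonds along the chain from an amide-type nitrogen), and the measured step is a number 0.10 log units higher from compound 3 to compound 2 (within the scatter). The unmeasured compound 4 `CC(C)(C)NC(=O)NO` stands to compound 1 in a change of the same kind, methyl in place of hydrogen on a saturated chain carbon bound to an amide-type nitrogen and two saturated chain carbons: the methyl again enters on a saturated chain carbon, but here that carbon is bound to an amide-type nitrogen and two saturated chain carbons, rather than three bonds along the chain from an amide-type nitrogen.

On the ground that compound 3 to compound 2 gave a number 0.10 log units higher from compound 3 to compound 2 (within the scatter), the step from compound 1 to compound 4 in this assay is expected to be a number 0.20 log units higher from compound 1 to compound 4 (within the scatter), with wider uncertainty for the different surroundings of the place. Compound 4 is therefore estimated to give 0.4, with a range from 0.1 to 0.7.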

Compound 4, partition coefficient: 0.5
Beside the measured number, compound 4's estimate is 0.10 log units below it; measured number inside the range.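

Carried onto the core of compound 1 in this assay, methyl in place of hydrogen on a saturated chain carbon bound to an amide-type nitrogen and two saturated chain carbons gives a number 0.30 log units higher from compound 1 to compound 4 (within the scatter), while on the other core, methyl in place of hydrogen on a saturated chain carbon, three bonds along the chain from an amide-type nitrogen, gave a number 0.10 log units higher from compound 3 to compound 2 (within the scatter). Among these compounds, both steps are printed as within the scatter, so the two pairs show only that this change stayed inside the usual spread of repeated measurements on each core; they do not show a fixed size for the step, nor that it would transfer to any other core, since the methyl enters at a different place in each pair and only these two pairs are at hand. Nothing available bears on why either step has the size it has.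

The compounds shown leave open how a longer chain, or a chain carrying an amine or a carboxylic acid, would stand in this assay. They also leave open whether the same methyl change would give a step beyond the scatter on a core with such a group.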